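This account rests on a few compounds, and the source may have more. Where it says the series, first, only, none or still open, it means among the compounds named here.

In a functional assay on MCF7 cells (Homo sapiens) for cytotoxicity, read by fluorescence, with a stated time of 72 h (a higher number here means a weaker inhibitor, a lower number a stronger inhibitor), compound 1 `CSc1nc(NCc2ccc(-c3ccccn3)cc2)c2[nH]nc(C(C)C)c2n1` gives 819 nM and compound 2 `CC(C)c1n[nH]c2c(NCc3ccc(-c4ccccn4)cc3)nc(S(C)(=O)=O)nc12` gives 460 nM while compound 3 `CC(C)c1n[nH]c2c(NCc3ccc(-c4ccccn4)cc3)nc(NCC(N)CO)nc12` gives 310 nM on the same shared core. These compounds differ only in the group on one aromatic carbon, which lies between two ring nitrogen atoms. Compound 3 stands within the scatter of one neighbour and clear of the other, as two steps show: a 1.5-fold lower number from compound 2 to compound 3 (0.17 log units; within the scatter) and a 2.6-fold lower number from compound 1 to compound 3 (0.42 log units; beyond the scatter) in the same series.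

Compound 4 `CC(C)c1n[nH]c2c(NCc3ccc(-c4ccccn4)cc3)nc(N3CCNCC3)nc12` is changed at that same carbon, and the change is a group of 6 heavy atoms (4 carbon, 2 nitrogen; one six-membered non-aromatic ring with 2 hetero atoms) in place of a group of 6 heavy atoms (3 carbon, 2 nitrogen, 1 oxygen; no ring), on an aromatic carbon on the ring shared by the series. Piperazin-1-yl thus enters where the open chain leaves. All three measured steps bear on this place, but none of them brings in a ring, so they offer only a rough guide. One of them, a 1.8-fold lower number from compound 1 to compound 2 (0.25 log units; within the scatter) in this series, stays within the scatter, and the largest, a 2.6-fold lower number from compound 1 to compound 3 (0.42 log units; beyond the scatter) at this carbon, is only modest. On that basis no step beyond the scatter is expected in this assay, and the estimated change is a 1.0-fold lower number from compound 3 to compound 4 (0.01 log units; within the scatter) with no direction favoured. For compound 4 the estimate is 300 nM with an expected range from 110 nM to 800 nM around it.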

Compound 4, half-maximal inhibitory concentration: 21 nM
Compound 4: the middle estimate sits 14-fold (1.15 log units) above what was measured; the measured number lies below the stated range.
By their numbers in this assay, from the lowest: compound 4; then compounds 3, 2 and 1 (each within the scatter of the next, the first and the last beyond it).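

Among the compounds shown here, at this carbon between two ring nitrogen atoms, this assay proves far more sensitive than the earlier compounds suggested: piperazin-1-yl gives a 15-fold lower number from compound 3 to compound 4 (1.17 log units; beyond the scatter), a 22-fold lower number from compound 2 to compound 4 (1.34 log units; beyond the scatter) and a 39-fold lower number from compound 1 to compound 4 (1.59 log units; beyond the scatter), each much larger than any step among the three non-ring groups. The open chain and piperazin-1-yl hold the same count of heavy atoms, so that count alone does not set the number at this position; the change also brings in a ring and lowers the counts of hydrogen-bond donors and acceptors. Nothing shown here explains why this change lowers the number so much.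

Going by these compounds, it remains open whether the large step needs both nitrogen atoms of the piperazin-1-yl ring, which morpholin-4-yl or piperidin-1-yl at the same carbon would test, or whether an open chain with the same atoms as the ring could match it. On these data alone, it is also open whether a methyl group on the outer nitrogen of piperazin-1-yl, or a seven-membered homopiperazine ring in its place, would keep the number of compound 4.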